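Removing a Methyl from an Aromatic Ether in TK-10 Cells

The source may hold more compounds than are shown below. What is called first, only, known or untested is meant among the compounds shown, and "the series" means these compounds.

Measured compounds:
compound 1 `COc1cc(C)cc(-c2c(-c3ccnc(-c4ccc(N(C)C)cc4)c3)cnn2CC#N)c1` — > 100000 nM
compound 2 `COc1cc(C)cc(-c2nn(CC#N)cc2-c2ccnc(-c3ccc(N(C)C)cc3)c2)c1` — 78900 nM

Two compounds share the same substituents on the same core and differ only in how the two aryl groups are arranged around it. In a functional assay on TK-10 cells (Homo sapiens) for inhibition, read by sulforhodamine B assay, with a stated time of 48 h (a lower number here means a stronger inhibitor of growth, a higher number a weaker inhibitor of growth), compound 1 gives only a limit, > 100000 nM, and no number. In this assay, within the data shown here, compound 2 gives 78900 nM, the only actual number in the set. The other entry is the limit noted for compound 1 (the limit of > 100000 nM in this assay, at which 1 of the 2 values shown sits). Among the measured compounds shown here, no two measured compounds differ in a single place, so no measured step can guide the next change.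

Compound 3 `Cc1cc(O)cc(-c2nn(CC#N)cc2-c2ccnc(-c3ccc(N(C)C)cc3)c2)c1` keeps the arrangement of compound 2 and alters one group: hydrogen in place of methyl on an oxygen on an aromatic ring. For the measured compounds named here, the change is small in count, methoxy to hydroxy on the 3-methoxy-5-methylphenyl ring, and the data give no measured step that shows what such a change does here. The step from compound 2 to compound 3 is expected to be modest, a 1.3-fold lower number from compound 2 to compound 3 (0.12 log units; within the scatter), and could fall either way within the scatter. Compound 3 is therefore estimated at 60000 nM, with a range from 15000 nM to 200000 nM.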

Compound 3, concentration for total growth inhibition: 57800 nM
Compound 3: middle estimate off by 1.0-fold (0.02 log units), on the high side; the measured number falls inside the stated range.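

With this result the set gains its first measured step between two compounds that differ in one place. In this assay, the change from methoxy to hydroxy on the 3-methoxy-5-methylphenyl ring gives a 1.4-fold lower number from compound 2 to compound 3 (0.14 log units; within the scatter), so at this position, the methyl on the oxygen can give way to hydrogen without a shift that stands clear of repeated measurement. Compound 1 remains a limit and not a number: the limit of > 100000 nM in this assay, at which 1 of the 3 values shown sits.

The compounds shown leave open whether another group on that oxygen, such as an ethyl or a longer chain, or an amine in place of the hydroxy, would move the number beyond the scatter. They also leave open whether methoxy to hydroxy would read the same way in the arrangement of compound 1, and whether this single step says anything about the same change elsewhere on the shared core.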